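This account rests on a few compounds, and the source may have more. Where it says the series, first, only, none or still open, it means among the compounds named here.

Compound 2 `Cc1cc(C)c(NC(=O)N(Cc2cccc(-c3csc(C)n3)c2)C2CCCCCC2)c(C)c1` and compound 1 `Cc1cc(C)c(NC(=O)N(Cc2ccc(-c3ccccc3)s2)C2CCCCCC2)c(C)c1` share the same core and were both tested in an assay on microsomes from intestine for inhibition of acyl-CoA:cholesterol acyltransferase (Oryctolagus cuniculus); on this read-out higher numbers stand for weaker inhibition and lower numbers for stronger inhibition. Compound 2 gives 180 nM, the higher of the two numbers, while compound 1 gives 46 nM; that gap lies beyond the usual scatter. Compound 3 `Cc1cc(C)c(NC(=O)N(Cc2cccc(-c3nnn(C)n3)c2)C2CCCCCC2)c(C)c1` differs from compound 2 in one place: 2-methyl-2H-tetrazol-5-yl in place of 2-methyl-1,3-thiazol-4-yl on an aromatic carbon. Going by the values given here, no measured pair shows this exchange, so its effect is open. Compound 3 is expected to give 320 nM in this assay, with a range from 110 nM to 950 nM. The step from compound 2 to compound 3 is therefore estimated at a 1.8-fold higher number from compound 2 to compound 3 (0.25 log units; within the scatter), a modest weakening that may not exceed the scatter.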

Compound 3, half-maximal inhibitory concentration: 100 nM
Beside the measured number, compound 3's estimate is 3.2-fold (0.51 log units) above it; measured number outside the range, below it.
By their numbers in this assay, from the lowest: compound 1; then compounds 3 and 2 (each within the scatter of the next).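

In this assay the exchange of 2-methyl-1,3-thiazol-4-yl for 2-methyl-2H-tetrazol-5-yl gives a 1.8-fold lower number from compound 2 to compound 3 (0.26 log units; within the scatter) and so does not separate the two groups. On this aromatic carbon, a five-membered aromatic ring with 4 hetero atoms and no sulfur therefore reads the same as one with 2 hetero atoms, within the scatter. No supporting data are available to explain this result. Going by these compounds, how a group of another kind, such as an amine or a carboxylic acid, would read on this aromatic carbon remains open. On these data alone, whether a five-membered ring is needed here at all also remains open.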